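A few compounds are considered here, and "the series" means these few. Any claim that something is new, unique, unknown or untested is made for them only; others in the source may bear on it.

Compound 1, `CCCCCCOC(=O)c1cccc(-c2cc(C(=O)Nc3ccncc3)ccc2CN)c1`, in an assay on isolated protein for inhibition of Rho-associated protein kinase 2 (Homo sapiens), read by radiometric assay (on this read-out lower numbers stand for stronger inhibition and higher numbers for weaker inhibition), gives 22 nM.
Compound 2, `CC(C)OCCOC(=O)c1cccc(-c2cc(C(=O)Nc3ccncc3F)ccc2CN)c1`, in this assay gives 37 nM.

These two numbers lie within the usual scatter of each other, so on the data shown compound 2 cannot be set apart from compound 1; both are potent inhibitors in this assay.

Compound 3, `CCCOC(=O)c1cccc(-c2cc(C(=O)Nc3ccncc3F)ccc2CN)c1`, has not yet been measured. It differs from compound 2 in one place: methyl in place of isopropoxy on a saturated chain carbon, two bonds along the chain from an oxygen next to a carbonyl group. The ester chain is thus shortened and its ether oxygen removed, while the amide, the fluorinated ring and the aminomethyl group of the shared core stay as they are.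

Among the compounds with values here, no pair of measured compounds shows this exact change, so the size of the step must be guessed. Compound 1, which carries a longer, oxygen-free chain beyond the oxygen next to the carbonyl group and differs elsewhere as well, gives 22 nM, which does not suggest that this part of the molecule moves the number far. The step from compound 2 to compound 3 is therefore expected to be small, a 1.2-fold lower number from compound 2 to compound 3 (0.09 log units; within the scatter), in no clear direction beyond the scatter. Compound 3 is estimated at 30 nM, with a likely range from 12 nM to 75 nM.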

Compound 3, half-maximal inhibitory concentration: 5.1 nM
The estimate for compound 3 lay 5.9-fold (0.77 log units) above the measured number, and the stated range ends above it.
By their numbers in this assay, from the lowest: compound 3; then compounds 1 and 2 (each within the scatter of the next).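

In this assay, putting methyl in place of isopropoxy on this saturated chain carbon turns the 2-isopropoxyethoxy chain of the ester into a propoxy chain and gives a 7.3-fold lower number from compound 2 to compound 3 (0.86 log units; beyond the scatter). With the rest of the molecule unchanged, this shows that the far end of the ester chain is not a silent part of the molecule: what sits on this carbon can clearly shift the number, and here the group with 1 heavy atom goes with the lower number, not the group with 4. The compounds shown offer no independent measurement that explains why the number falls.

This one change shortens the chain and removes its ether oxygen together, so the compounds shown cannot tell which of the two matters, or whether both do. Also open, as far as these compounds go, is how a butoxy chain, which has no ether oxygen, or a 2-methoxyethoxy chain, which keeps one, would compare with compound 3 on the same fluorinated core.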